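This account rests on a few compounds, and the source may have more. Where it says the series, first, only, none or still open, it means among the compounds named here.

Measured so far in a functional assay for inhibition, using microsomes, tested at 200 ug/mL; on this read-out higher numbers stand for a weaker effect at the one concentration tested and lower numbers for a stronger effect:
compound 1 `CCOC(=O)C1=C(C)N(c2ccc(F)cc2)C=CC1c1ccccc1` gives -35.8%
compound 2 `CCOC(=O)C1=C(C)N(c2ccc(Br)cc2)C=CC1c1ccccc1` gives -32.1%
compound 3 `COC(=O)C1=C(C)N(c2ccc(OC)cc2)C=C(C)C1c1ccccc1` gives -28.9%

Compound 3 has the highest of the three numbers, yet its gaps to compound 2 and to compound 1 are both within the usual scatter, so the three compounds stand level in this assay. Compound 4 `COC(=O)C1=C(C)N(c2cccc(C)c2C)C=C(C)C1c1ccccc1` differs from compound 3 in one place: 2,3-dimethylphenyl in place of 4-methoxyphenyl on an amine nitrogen in a ring. Going by the values given here, the only measured step, a number 3.7 percentage points higher from compound 1 to compound 2 (within the scatter), also altered the aromatic group on the ring nitrogen and stayed within the scatter. On that basis no step beyond the scatter is expected in this assay for compound 4. Compound 4 is therefore estimated to give -30%, expected to lie between -45% and -15%. The expected step of a number 1.1 percentage points lower from compound 3 to compound 4 (within the scatter) is within the scatter.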

Compound 4, a percentage reported as activity, at one concentration (the size of the read-out at that concentration, not a potency): -33.1%
For compound 4 the middle estimate is 3.1 percentage points above the measured one, within the range that was stated.
By their numbers in this assay, from the lowest: compounds 1, 4, 2 and 3 (each within the scatter of the next).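

In this assay the step on the amine nitrogen in the ring is a number 4.2 percentage points lower from compound 3 to compound 4 (within the scatter). Going by these compounds alone, the only earlier step at this place exchanged one halogen for another, whereas this one shows that 2,3-dimethylphenyl, with no hydrogen-bond acceptor, stands level with 4-methoxyphenyl, which has one. Nothing available here offers a reason for this result. Still open, on these data alone, is whether a phenyl ring carrying an amine or a carboxylic acid would stay level at this nitrogen. The same question applies to a longer alkyl chain in place of the aromatic group.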